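A few compounds are considered here, and "the series" means these few. Any claim that something is new, unique, unknown or untested is made for them only; others in the source may bear on it.

Series notes. Compound 1 `Cc1cccc(-n2nncc2CN2C(=O)C3(C(C#N)=C(N)Oc4c3c3nc5ccccc5nc3c3ccccc43)c3ccccc32)c1` in a functional assay on A549 cells (Homo sapiens) for antiproliferative activity, read by MTT assay, with a stated time of 48 h (on this read-out lower numbers stand for stronger inhibition and higher numbers for weaker inhibition), gives 39600 nM, a weak result. Compound 2 `CC(=O)Nc1ccc(-n2nncc2CN2C(=O)C3(C(C#N)=C(N)Oc4c(N)cc5nc6ccccc6nc5c43)c3ccccc32)cc1` returns only a limit in this assay, > 50000 nM, so no number is known for it; compound 2 stands at the limit of > 50000 nM in this assay, at which 1 of the 2 values shown sits. For the measured compounds named here, no step between compounds differing in one place has been measured. Compound 3 `N#CC1=C(N)Oc2c(N)cc3nc4ccccc4nc3c2C12C(=O)N(Cc1cnnn1-c1cc(Cl)ccc1Cl)c1ccccc12` carries 2,5-dichlorophenyl in place of 4-acetamidophenyl on an aromatic nitrogen. From a limit as the starting point, the step of an at least 1.2-fold lower number from compound 2 to compound 3 (0.09 log units; that floor lies within the scatter) is expected to be small, in either direction or none beyond the scatter. Compound 3 is therefore expected near 40000 nM, within a range from 15000 nM to 60000 nM.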

Compound 3, half-maximal inhibitory concentration: 10900 nM
Compound 3: middle estimate off by 3.7-fold (0.56 log units), on the high side; the whole stated range lies above it.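

In this assay, for the compounds shown here, 2,5-dichlorophenyl in place of 4-acetamidophenyl on the aromatic nitrogen gives an at least 4.5-fold lower number from compound 2 to compound 3 (0.66 log units; beyond the scatter), the first measured step at this position. It shows that the group carried here can shift the read-out beyond the scatter on this core. The true size of the step stays unknown because compound 2 stands at a limit: the limit of > 50000 nM in this assay, at which 1 of the 3 values shown sits.

On these data alone, whether the shift follows the two chlorines or the loss of the acetamido group remains open. An unsubstituted phenyl or a phenyl with a single chlorine on the same core would separate the two.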